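Swapping Acetyl for Trifluoromethoxy in a Urea Series

The source may report more compounds than this note shows. Statements on the series, on what has been measured and on what is new or still open speak of the compounds shown alone.

Three ureas built on one shared core have been tested in an ADME assay on HEK293 cells (Homo sapiens) for cytotoxicity, with a stated time of 72 h; on this read-out lower numbers stand for an effect already at smaller amounts and higher numbers for an effect only at larger amounts of compound. Compound 1 `Cc1cc(NC(=O)Nc2ccccc2F)c2ccccc2n1` carries a fluoro group, compound 2 `CSc1ccccc1NC(=O)Nc1cc(C)nc2ccccc12` carries methylsulfanyl in its place, and compound 3 `CC(=O)c1ccc(NC(=O)Nc2cc(C)nc3ccccc23)cc1` carries an acetyl group. In this assay compound 1 gives only a limit, > 25000 nM. Compound 2 likewise reaches only the limit > 25000 nM. Compound 3 also stops at the limit > 25000 nM, so it stands where the two other values shown stand as well. For the measured compounds named here, the single step between measured neighbours, a step that the two limits leave unreadable from compound 1 to compound 2, cannot be sized. What the data offer is the limit of > 25000 nM in this assay, at which 3 of the 3 values shown sit.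

Compound 4 `Cc1cc(NC(=O)Nc2ccc(OC(F)(F)F)cc2)c2ccccc2n1` is not yet measured. It differs from compound 3 in one place: trifluoromethoxy in place of acetyl on an aromatic carbon. Going by the values given here, no measured step covers this change, and the one step that exists has no readable size, so no direction can be set for this assay, and a further limit is the likeliest outcome. Compound 4 is therefore expected to give about 30000 nM, within 15000 nM to 100000 nM. This expectation amounts to a step that the limit leaves unreadable from compound 3 to compound 4, which is meant as no change beyond the scatter.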

Compound 4, half-maximal effective concentration: 14000 nM
Compound 4: middle estimate off by 2.1-fold (0.33 log units), on the high side, outside the stated range (below it).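

In this assay, trifluoromethoxy in place of acetyl on an aromatic carbon, para to a large group, gives the series its first step with a readable size: an at least 1.7-fold lower number from compound 3 to compound 4 (0.25 log units; that floor lies within the scatter). Only the floor of this step is known, and since that floor lies within the scatter, the change cannot yet be said to exceed the normal variation between repeats, although the true gap may be larger. Even so, compound 4 is the only compound shown with a measured number rather than a limit, which sets it apart from the others: the limit of > 25000 nM in this assay, at which 3 of the 4 values shown sit.

The compounds shown leave open whether this number is particular to trifluoromethoxy or would also appear with another group in that place, such as an amine or a carboxylic acid. As far as these compounds go, how a longer chain there would read also remains unknown.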